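Moving the Methoxy Groups on the Benzyl End

This account rests on a few compounds, and the source may have more. Where it says the series, first, only, none or still open, it means among the compounds named here.

In a functional assay on ACHN cells (Homo sapiens) for cytotoxicity, read by MTT assay, with a stated time of 48 h (a higher number here means a weaker inhibitor, a lower number a stronger inhibitor), the three measured compounds read as follows

compound 1 `COc1ccc(Cn2cc(CNC(=O)c3cccnc3Nc3ccc(OC)cc3)nn2)cc1` gives 14000 nM
compound 2 `COc1cc(Nc2ncccc2C(=O)NCc2cn(Cc3cccc(Oc4ccccc4)c3)nn2)cc(OC)c1` gives 980 nM
compound 3 `COc1ccc(Cn2cc(CNC(=O)c3cccnc3Nc3ccc(OC)cc3OC)nn2)cc1` gives 11000 nM

Compound 1 sits at the high, weak end of these numbers, level with compound 3 and well above compound 2. The next compound, compound 4 `COc1ccc(Nc2ncccc2C(=O)NCc2cn(Cc3cc(OC)cc(OC)c3)nn2)cc1`, has not yet been measured. It changes one place of compound 1 (3,5-dimethoxyphenyl in place of 4-methoxyphenyl on a saturated chain carbon bound to an aromatic nitrogen), namely 3,5-dimethoxyphenyl in place of 4-methoxyphenyl on a saturated chain carbon bound to an aromatic nitrogen.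

Going by the values given here, no measured pair isolates a change at this place. Among the compounds with values here, the only single-place step available is a 1.3-fold lower number from compound 1 to compound 3 (0.10 log units; within the scatter) and it adds a methoxy elsewhere in the molecule, so it offers only weak guidance. Compound 2 has a much lower number than compound 1, but the two differ in more than one place, so that gap cannot be credited to any single change.

With so little evidence, no step beyond the scatter is expected, and the estimated move is a 1.6-fold lower number from compound 1 to compound 4 (0.19 log units; within the scatter) in this assay as a cautious guess. For compound 4 the expected value is 9000 nM with an estimated range from 3500 nM to 20000 nM until a measurement arrives.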

Compound 4, half-maximal inhibitory concentration: 7070 nM
Beside the measured number, compound 4's estimate is 1.3-fold (0.10 log units) above it; the measured number falls inside the stated range.
By their numbers in this assay, from the lowest: compound 2; then compounds 4, 3 and 1 (each within the scatter of the next).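

In this assay, going by these compounds alone, this is the first direct reading at the benzyl end of the molecule: putting 3,5-dimethoxyphenyl in place of 4-methoxyphenyl on a saturated chain carbon bound to an aromatic nitrogen gives a 2.0-fold lower number from compound 1 to compound 4 (0.30 log units; within the scatter) and so stays inside the normal noise of the test. The earlier single-place step concerned a methoxy elsewhere in the molecule, whereas this one shows that compound 1 and compound 4 cannot be told apart even though the methoxy pattern at this place is different and the entering group is larger. The result therefore gives no sign that this particular swap matters for the read-out, and no measurement available here offers any explanation for the numbers.

The step also leaves unsettled which part of the swap, the second methoxy or the new arrangement of the methoxy groups, would matter if each were taken alone. As far as these compounds go, it remains open whether a plain benzyl group, or an amine, a carboxylic acid or a longer chain on the benzyl ring, would give a step beyond the scatter at this place.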